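Methyl for Hydrogen at Two Different Places

The source may report more compounds than this note shows. Statements on the series, on what has been measured and on what is new or still open speak of the compounds shown alone.

Compound 1 `COc1ccccc1/C=C/C=N/N1C(=S)NC2C1N(C)C(=O)N2c1ccccc1` and compound 2 `CCN1C(=O)N(c2ccccc2)C2NC(=S)N(/N=C/C=C/c3ccccc3OC)C21` share a core and differ by one group: methyl in place of hydrogen on a saturated chain carbon bound to an amide-type nitrogen in a ring. In an ADME assay on HEK293 cells (Homo sapiens) for inhibition, read by MTT assay, with a stated time of 72 h (a lower number here means a stronger inhibitor, a higher number a weaker inhibitor), compound 1 gives 230 nM, and compound 2 gives 57500 nM; the step of a 250-fold higher number from compound 1 to compound 2 (2.40 log units; beyond the scatter) is large. Compound 3 `CCN1C(=O)N(CC)C2C1N=C(SC)N2/N=C/C=C/c1ccccc1[N+](=O)[O-]` and compound 4 `CCSC1=NC2C(N(CC)C(=O)N2CC)N1/N=C/C=C/c1ccccc1[N+](=O)[O-]` make up a second pair, and how their core differs from the core of compound 1 is not broken down here. Between them the difference is methyl in place of hydrogen on a saturated chain carbon bound to a sulfur. This is the same kind of change as before, but the place is not the same: the carbon sits bound to a sulfur rather than to an amide-type nitrogen in a ring. In this assay compound 3 gives "not determined" (no result reported), so nothing here anchors the second pair. Compound 4 is expected to give roughly 10000 nM, estimated between 500 nM and 100000 nM.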

Compound 4, half-maximal inhibitory concentration: 221000 nM
Compound 4: middle estimate off by 22-fold (1.34 log units), on the low side; the whole stated range lies below it.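

Compound 3 gives no single number to set against compound 4, so no step can be read between them. From the compounds shown here alone, whether methyl for hydrogen on a saturated chain carbon bound to a sulfur changes the result at all stays open. Nothing available explains the result for compound 4.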